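This account rests on a few compounds, and the source may have more. Where it says the series, first, only, none or still open, it means among the compounds named here.

Compound 1 `COc1cc(-c2cc(/C=C/C(=O)c3ccc(N)cc3)[nH]n2)cc(OC)c1OC` was examined in a functional assay on T47D cells (Homo sapiens) for cytotoxicity, read by sulforhodamine B assay, with a stated time of 48 h, tested at 100 uM (on this read-out higher numbers stand for a weaker effect at the one concentration tested and lower numbers for a stronger effect), where compound 1 gives -47%, the highest of the two numbers recorded. Compound 2 `COc1ccc(-c2cc(/C=C/C(=O)c3ccc(OC)c(OC)c3)[nH]n2)cc1` sits lower: in this assay compound 2 gives -83%, a gap beyond the scatter. Compound 3 `COc1cc(-c2cc(/C=C/C(=O)c3ccc(Cl)c(Cl)c3)[nH]n2)cc(OC)c1OC` differs from compound 1 by 3,4-dichlorophenyl in place of 4-aminophenyl on a carbonyl carbon. Among the measured compounds shown here, with no measured step of this kind to rest on, a moderate downward shift is expected, yet it may also stay within the scatter. The expected step in this assay a number 15 percentage points lower from compound 1 to compound 3 (beyond the scatter) leads to an estimate for compound 3 of -62%, within the range -95% to -25%.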

Compound 3, a percentage reported as activity, at one concentration (the size of the read-out at that concentration, not a potency): -36%
Compound 3: middle estimate off by 26 percentage points, on the low side; low and high end bracket the measured number.
By their numbers in this assay, from the lowest: compound 2; then compound 1; then compound 3.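

In this assay, 3,4-dichlorophenyl in place of 4-aminophenyl on a carbonyl carbon gives a number 11 percentage points higher from compound 1 to compound 3 (beyond the scatter) as a modest move toward a weaker effect, so this position responds to the change of aryl group. The effect does not depend on keeping the 4-aminophenyl group, since compound 3 gives -36% without it. Nothing measured here accounts for the shift. The compounds shown leave open whether the step follows from losing the amine or from gaining the two chlorines. A lone 4-chlorophenyl or an unsubstituted phenyl on that carbonyl carbon would separate these two readings.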